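This account rests on a few compounds, and the source may have more. Where it says the series, first, only, none or still open, it means among the compounds named here.

Compound 1 `O=C(Nc1nc2ccccc2s1)c1cn(-c2ccccc2)nc1-c1ccccc1` and compound 2 `O=C(Nc1nc2ccc(Cl)cc2s1)c1cn(-c2ccccc2)nc1-c1ccccc1` share one core and differ at a single aromatic carbon. In an ADME assay on HEK-293T cells (Homo sapiens) for cytotoxicity, read by MTT assay, with a stated time of 72 h (a lower number here means a stronger inhibitor, a higher number a weaker inhibitor), compound 1 gives only a limit, > 50000 nM. In this assay compound 2 gives 21300 nM. Going by the values given here, the step of an at least 2.3-fold lower number from compound 1 to compound 2 (0.37 log units; beyond the scatter) is the sole measured step, and its true size is open because one end of it is the limit of > 50000 nM in this assay, at which 1 of the 2 values shown sits. Among the compounds with values here, compound 2 therefore stands as the one compound with an actual number rather than a limit.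

Compound 3 `COc1ccc2nc(NC(=O)c3cn(-c4ccccc4)nc3-c3ccccc3)sc2c1` is the next step: methoxy in place of chloro on an aromatic carbon. Within the data shown here, no measured step exchanges chloro for methoxy, so the expectation rests only on the step from hydrogen to chloro, which gave a lower number. Taking the chloro away may undo part of that, so for compound 3 in this assay a somewhat higher number is expected, a 1.6-fold higher number from compound 2 to compound 3 (0.22 log units; within the scatter), with an estimate of 35000 nM, between 12000 nM and 90000 nM.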

Compound 3, half-maximal inhibitory concentration: > 50000 nM
Compound 3: no number, only a limit; the forecaster's own chance of this, stated with the estimate: 40%; at least 1.4-fold (0.15 log units) between middle value and limit.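

The step of an at least 2.3-fold higher number from compound 2 to compound 3 (0.37 log units; beyond the scatter) shows that a substituent at this position does not by itself lower the number in this assay, since methoxy, which brings a hydrogen-bond acceptor that chloro lacks, does not keep what chloro gave. On these data alone, compound 3 gives only a limit, so the true size of this step is unknown. Among the three compounds shown, chloro is thus the only group at this position with an actual number, whereas the earlier pair could compare chloro only with hydrogen.

As far as these compounds go, the step from compound 1 to compound 3 cannot be read, because both of its ends are limits: the limit of > 50000 nM in this assay, at which 2 of the 3 values shown sit. Whether another group here, such as an amine or a carboxylic acid, would give a lower number as chloro does remains open.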